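Thiophene replacement on the shared core: cytotoxicity expectation

The source may hold more compounds than are shown below. What is called first, only, known or untested is meant among the compounds shown, and "the series" means these compounds.

Compound 1 `Cc1ccsc1CN[C@@H]1C[C@H]2C[C@@H]([C@H]1C)C2(C)C` carries a 3-methylthiophen-2-yl on the saturated chain carbon bound to the amine nitrogen. In an ADME assay on MDCK cells (Canis lupus familiaris) for cytotoxicity, read by microscopy, with a stated time of 48 h (on this read-out lower numbers stand for higher toxicity in this test and higher numbers for lower toxicity in this test), compound 1 gives 10000 nM, the lowest of the three numbers measured. Compound 2 `C=Cc1ccsc1CN[C@@H]1C[C@H]2C[C@@H]([C@H]1C)C2(C)C` gives 50000 nM, and compound 3 `CCCCc1ccsc1CN[C@@H]1C[C@H]2C[C@@H]([C@H]1C)C2(C)C` gives 25000 nM. Both neighbours sit higher: a 5.0-fold higher number from compound 1 to compound 2 (0.70 log units; beyond the scatter) and a 2.5-fold higher number from compound 1 to compound 3 (0.40 log units; beyond the scatter), while a 2.0-fold lower number from compound 2 to compound 3 (0.30 log units; within the scatter).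

Compound 4 `C[C@H]1[C@H](NCc2ccsc2)C[C@H]2C[C@@H]1C2(C)C` differs from compound 1 by thiophen-3-yl in place of 3-methylthiophen-2-yl on a saturated chain carbon bound to an amine nitrogen. Among the measured compounds shown here, no measured step removes the methyl or shifts the ring attachment, so the two steps from compound 1 bear only loosely: each altered the group on the thiophene ring and each raised the number, by modest amounts. For the measured compounds named here, with no direct precedent, the expected step in this assay from compound 1 to compound 4 is small and uncertain in direction, a shift around a 1.5-fold higher number from compound 1 to compound 4 (0.18 log units; within the scatter). Compound 4 is therefore estimated at 15000 nM, with a range from 5000 nM to 50000 nM.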

Compound 4, minimum cytotoxic concentration: 50000 nM
The estimate for compound 4 lay 3.3-fold (0.52 log units) below the measured number; measured number inside the range.
By their numbers in this assay, from the lowest: compound 1; then compounds 3, 2 and 4 (each within the scatter of the next).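

In this assay, the step of a 5.0-fold higher number from compound 1 to compound 4 (0.70 log units; beyond the scatter) shows that the higher number does not require a group on the thiophene ring beyond the attachment to the saturated chain carbon bound to the amine nitrogen: thiophen-3-yl carries none. Among the four compounds, compound 1 with its 3-methylthiophen-2-yl remains the lowest, and no compound goes against this, although the change in compound 4 removes the methyl and moves the ring attachment at once. Nothing shown bears on why the number moves.

The compounds shown leave open how the step divides between loss of the methyl and the shift in attachment, which thiophen-2-yl on the same carbon would help to separate. Also open, on these data alone, is how a phenyl ring in this place would read.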